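Methoxy in Place of Hydrogen: Expectation for Compound 4

This account rests on a few compounds, and the source may have more. Where it says the series, first, only, none or still open, it means among the compounds named here.

Compound 1 `C/C=C/COc1cc(/C=C\c2cc(OC)c(OC)c(OC)c2)ccc1OC` gives 161000 nM in a functional assay on HT-29 cells (Homo sapiens) for inhibition, read by MTT assay, with a stated time of 3 days; on this read-out lower numbers stand for stronger inhibition and higher numbers for weaker inhibition.
Compound 2 `COc1ccc(/C=C\c2cc(OC)c(OC)c(OC)c2)cc1OCc1ccc(Br)cc1` gives 108000 nM in this assay.
Compound 3 `COc1ccc(/C=C/CCCOc2cc(/C=C\c3cc(OC)c(OC)c(OC)c3)ccc2OC)cc1` gives 47000 nM in this assay.

Among these three, compound 3 has the lowest number: the step of a 3.4-fold lower number from compound 1 to compound 3 (0.53 log units; beyond the scatter) and the step of a 2.3-fold lower number from compound 2 to compound 3 (0.36 log units; beyond the scatter) both lie beyond the scatter, whereas the step of a 1.5-fold lower number from compound 1 to compound 2 (0.17 log units; within the scatter) does not. Compound 4 `COCOc1ccc(/C=C/CCCOc2cc(/C=C\c3cc(OC)c(OC)c(OC)c3)ccc2OC)cc1` differs from compound 3 by methoxy in place of hydrogen on a saturated chain carbon bound to an oxygen on an aromatic ring.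

Within the data shown here, no measured step mirrors this change directly. The two steps that reach compound 3 swap whole groups on a saturated chain carbon bound to an oxygen on an aromatic ring and were modest; the change to compound 4 is far smaller, adding only what is counted above. The account therefore expects a step of no more than the usual scatter in this assay, with no preferred direction.

For compound 4 a value of 42000 nM is estimated, with a likely range from 16000 nM to 110000 nM. This corresponds to an expected step of a 1.1-fold lower number from compound 3 to compound 4 (0.05 log units; within the scatter), which is within the scatter.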

Compound 4, half-maximal inhibitory concentration: 7000 nM
Compound 4: middle estimate off by 6.0-fold (0.78 log units), on the high side; the measured number lies below the stated range.
By their numbers in this assay, from the lowest: compound 4; then compound 3; then compounds 2 and 1 (each within the scatter of the next).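

The step of a 6.7-fold lower number from compound 3 to compound 4 (0.83 log units; beyond the scatter) in this assay shows that the number responds strongly to a small change at this position: methoxy in place of hydrogen, which turns 4-methoxyphenyl into 4-(methoxymethoxy)phenyl. Although methoxy brings only 2 heavy atoms, this step is larger than either whole-group swap that reaches compound 3, so among these compounds the size of the group exchanged does not track the size of the step. Nothing in the information available accounts for this effect.

On these data alone, whether a hydroxy group, an ethoxy group or a longer chain in place of the methoxymethoxy group would go the same way remains open. As far as these compounds go, it is also open whether the same change would carry over to compound 2, which holds 4-bromophenyl instead.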